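The source may report more compounds than this note shows. Statements on the series, on what has been measured and on what is new or still open speak of the compounds shown alone.

Compound 2 `O=C(/N=C(/NC(=O)c1ccno1)[Se]Cc1ccccc1)c1ccno1` and compound 1 `CS/C(=N\C(=O)c1ccno1)NC(=O)c1ccno1` share a core and differ in one place: a group of 2 heavy atoms (1 carbon, 1 sulfur; no ring) in place of a group of 8 heavy atoms (7 carbon, 1 selenium; one six-membered aromatic ring of carbon only), on a carbon with a double bond to nitrogen. In a functional assay on HT-29 cells (Homo sapiens) for cytotoxicity, read by MTT assay, with a stated time of 72 h (a lower number here means a stronger inhibitor of growth, a higher number a weaker inhibitor of growth), compound 2 gives 6820 nM. In this assay compound 1 gives > 100000 nM, which is a limit of the assay and not a number. That change made an at least 14-fold higher number from compound 2 to compound 1 (1.16 log units; beyond the scatter), a step whose size rests on (the limit of > 100000 nM in this assay, at which 1 of the 3 values shown sits). Compound 3 `O=C(/N=C(/NC(=O)c1cc(-c2ccccc2)nc2ccccc12)[Se]Cc1ccccc1)c1cc(-c2ccccc2)nc2ccccc12` gives 6070 nM in this assay; the difference between its core and that of compound 2 is not broken down here. Compound 4 `CS/C(=N\C(=O)c1cc(-c2ccccc2)nc2ccccc12)NC(=O)c1cc(-c2ccccc2)nc2ccccc12` is not yet measured and differs from compound 3 by the same change: a group of 2 heavy atoms (1 carbon, 1 sulfur; no ring) in place of a group of 8 heavy atoms (7 carbon, 1 selenium; one six-membered aromatic ring of carbon only), on a carbon with a double bond to nitrogen. The expectation for compound 4 rests on the earlier step, an at least 14-fold higher number from compound 2 to compound 1 (1.16 log units; beyond the scatter), made on the other core. Compound 4 is therefore expected to give about 150000 nM in this assay, an estimated step of a 25-fold higher number from compound 3 to compound 4 (1.39 log units; beyond the scatter).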

Compound 4, concentration for 50% growth inhibition: 23700 nM
Compound 4: middle estimate off by 6.3-fold (0.80 log units), on the high side, outside the stated range (below it).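

The change to methylsulfanyl gave a 3.9-fold higher number from compound 3 to compound 4 (0.59 log units; beyond the scatter), so in this assay the direction of the step carried over from one core to the other. Its size did not carry over: the same change on two cores in this assay, an at least 14-fold higher number (1.16 log units; beyond the scatter) from compound 2 to compound 1 and a 3.9-fold higher number (0.59 log units; beyond the scatter) from compound 3 to compound 4, at least 3.7-fold (0.57 log units) apart, beyond the scatter of two such steps The earlier step and the gap are bounds and not exact sizes, and the two cores do not show why the steps differ: the limit of > 100000 nM in this assay, at which 1 of the 4 values shown sits.

The compounds shown leave open how much of the step follows from swapping selenium for sulfur and how much from losing the aromatic ring, which a benzylsulfanyl or a methylselanyl group on the same carbon would separate. They also leave open how large the step would be on any further core.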